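The source may report more compounds than this note shows. Statements on the series, on what has been measured and on what is new or still open speak of the compounds shown alone.

Compound 1 `CCOC(=O)CCCCCOc1cccc(CN(C(=O)c2ccc(-c3cnc(OC)nc3OC)cc2)C(C)C)c1` — > 26000 nM
Compound 2 `CCOC(=O)CCCCCOc1cccc(CN(C(=O)c2ccc(-c3cccc(OCc4ccccc4)c3)cc2)C(C)C)c1` — > 26000 nM

In an ADME assay on BJ cells (Homo sapiens) for cytotoxicity, read by CellTiter-Glo and resazurin assay, with a stated time of 72 h (a higher number here means that more compound is needed for the effect, a lower number that less compound is needed), compound 2 gives > 26000 nM, which is a limit of the assay rather than a number. Compound 1 likewise gives > 26000 nM in this assay, again a limit. Together the two values show (the limit of > 26000 nM in this assay, at which 2 of the 2 values shown sit). Compound 3 `CCOC(=O)CCCCCOc1cccc(CN(C(=O)c2ccc(-c3cccc(F)c3)cc2)C(C)C)c1` differs from compound 2 by fluoro in place of benzyloxy on an aromatic carbon. Within the data shown here, with no measured step available, the step in this assay is expected to be a number no higher from compound 2 to compound 3 (the limit leaves the size open), staying at the limit. Compound 3 is therefore estimated at about 26000 nM, within a range of 12000 nM to 60000 nM.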

Compound 3, half-maximal effective concentration: > 26000 nM
Compound 3: a limit, no number (the forecaster's own chance of this, stated with the estimate: 85%); the middle value sits exactly at the limit.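

Among these compounds, compound 3, like compound 1 and compound 2, reaches only a limit in this assay, so no step to compound 3 from either of the others can be read: the limit of > 26000 nM in this assay, at which 3 of the 3 values shown sit. From the compounds shown here alone, what remains open is where the actual values of these three compounds lie, and whether exchanging these groups changes the read-out at all.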